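Triazole demethylation and metabolic stability in the series

The source may hold more compounds than are shown below. What is called first, only, known or untested is meant among the compounds shown, and "the series" means these compounds.

Compound 1 `CCn1ncc2c(F)cc(-c3ccc(C(CC)(CC)c4nnc(C)[nH]4)c(=O)[nH]3)cc21` in an ADME assay on microsomes from liver (Rattus norvegicus) for metabolic stability (on this read-out lower numbers stand for a shorter-lived compound and higher numbers for a longer-lived compound), gives > 3 h, which is a limit of the assay.
Compound 2 `CCn1ncc2c(F)cc(-c3ccc(C(CC)(CC)c4ncn(C)n4)c(=O)[nH]3)cc21` in this assay gives > 3 h, again a limit.
Compound 3 `CC(C)C(c1ncco1)c1ccc(-c2ccc3cccc(F)c3c2)[nH]c1=O` in this assay gives 0.0983 h.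

Compound 2 stands at the limit, (the limit of > 3 h in this assay, at which 2 of the 3 values shown sit), so only a floor is known for it. Among the measured compounds shown here, the single one-place step measured, a step that the two limits leave unreadable from compound 1 to compound 2, has limits at both ends and cannot be sized. Compound 4 `CCn1ncc2c(F)cc(-c3ccc(C(CC)(CC)c4nnc[nH]4)c(=O)[nH]3)cc21` differs from compound 2 by 4H-1,2,4-triazol-3-yl in place of 1-methyl-1H-1,2,4-triazol-3-yl on a saturated chain carbon bound to an aromatic carbon and two saturated chain carbons. No readable step bears on this change, and compound 3 belongs to a different core. Nothing here points to a step beyond the scatter. Compound 4 is therefore expected at about 3 h, between 1.2 h and 6 h, which means an expected step of a number no higher from compound 2 to compound 4 (the limit leaves the size open), and the assay may well return only a limit again.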

Compound 4, half-life: > 3 h
Compound 4 ended at the assay's limit (the forecaster's own chance of this, stated with the estimate: 65%); the middle value lies on the limit itself.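

No step among compound 1, compound 2 and compound 4 can be read, since all three stand at one limit: the limit of > 3 h in this assay, at which 3 of the 4 values shown sit.

On these data alone, how far each lies beyond that limit in this assay, and so whether moving or removing the methyl changes the read-out, stays open.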